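A few compounds are considered here, and "the series" means these few. Any claim that something is new, unique, unknown or untested is made for them only; others in the source may bear on it.

Working notes on the aryl group of the series, read in an ADME assay on microsomes from liver (Canis lupus familiaris) for metabolic stability; a higher number here means that the compound lasts longer, a lower number that the compound disappears faster. Compound 1 `Nc1nc(NCCNc2ncc(-c3ncc[nH]3)c(-c3cc(F)ccc3Cl)n2)ccc1[N+](=O)[O-]` gives > 0.5 h, which is a limit of the assay and not a number. Compound 2 `Nc1nc(NCCNc2ncc(-c3ncc[nH]3)c(-c3ccc(Br)cc3F)n2)ccc1[N+](=O)[O-]` gives > 0.5 h, which is also a limit. Compound 2 therefore has no readable position in the series, and both values shown sit at the limit of > 0.5 h in this assay, at which 2 of the 2 values shown sit.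

The next compound is compound 3 `Nc1nc(NCCNc2ncc(-c3ncc[nH]3)c(-c3cc(F)c(Cl)cc3F)n2)ccc1[N+](=O)[O-]`. It has 4-chloro-2,5-difluorophenyl in place of 4-bromo-2-fluorophenyl on an aromatic carbon, ortho to a 1H-imidazol-2-yl group, with the shared core unchanged: 4-chloro-2,5-difluorophenyl in place of 4-bromo-2-fluorophenyl on an aromatic carbon.

Going by the values given here, the only measured step that bears on this change is a step that the two limits leave unreadable from compound 1 to compound 2, which also exchanges the aryl group. It supplies neither a size nor a direction to carry over. No step beyond the scatter is therefore expected in this assay, and another report as a limit is the likely outcome for compound 3.

The expected step is a step that the limit leaves unreadable from compound 2 to compound 3. The estimate for compound 3 is 0.8 h, with an expected range from 0.45 h to 2 h.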

Compound 3, half-life: > 0.5 h
Compound 3 ended at the assay's limit; the forecaster's own chance of this, stated with the estimate: 80%; the middle value does not contradict the limit.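

In this assay compound 3 gives > 0.5 h, which is a limit of the assay and not a number. The steps from compound 1 and from compound 2 to compound 3 therefore cannot be read. The compounds shown leave open how the aryl group affects the half-life, as all three report only the same limit: the limit of > 0.5 h in this assay, at which 3 of the 3 values shown sit.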